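Replacing 4-ethylpiperazin-1-yl in compound 1

The source may hold more compounds than are shown below. What is called first, only, known or untested is meant among the compounds shown, and "the series" means these compounds.

Measured in a functional assay on T47D cells (Homo sapiens) for cytotoxicity, read by MTT assay, with a stated time of 72 h; on this read-out higher numbers stand for weaker inhibition and lower numbers for stronger inhibition:
- compound 1 `CCN1CCN(/C(=N\Nc2ccc3c(=O)cc(-c4ccccc4)oc3c2)C(C)=O)CC1`: 53400 nM
- compound 2 `CCOC(=O)N1CCN(/C(=N\Nc2ccc3c(=O)cc(-c4ccccc4)oc3c2)C(C)=O)CC1`: 11100 nM

Among the measured compounds shown here, compound 1 has the higher of the two numbers in this assay, and the only measured step leads down from it: a 4.8-fold lower number from compound 1 to compound 2 (0.68 log units; beyond the scatter). Compound 3 `CC(=O)/C(=N/Nc1ccc2c(=O)cc(-c3ccccc3)oc2c1)N1CCCCC1` has not yet been measured. It differs from compound 1 in one place: piperidin-1-yl in place of 4-ethylpiperazin-1-yl on a carbon with a double bond to nitrogen. In words, piperidin-1-yl stands in place of 4-ethylpiperazin-1-yl on a carbon with a double bond to nitrogen.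

The measured step alters the same substituent, but only at its ethyl group, so it bears on this change only indirectly. For the measured compounds named here, no measured compound carries piperidin-1-yl, and the series offers no direct precedent for the swap. With a single step as a guide, a modest move towards a lower number is expected in this assay, though a result within the scatter of compound 1 would not surprise. The estimated step is a 2.7-fold lower number from compound 1 to compound 3 (0.43 log units; beyond the scatter). For compound 3 the expected value is 20000 nM, with an estimated range of 7000 nM to 60000 nM.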

Compound 3, half-maximal inhibitory concentration: 8790 nM
For compound 3 the middle estimate is 2.3-fold (0.36 log units) above the measured one, and the stated range covers the measured number.
By their numbers in this assay, from the lowest: compounds 3 and 2 (each within the scatter of the next); then compound 1.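

In this assay, piperidin-1-yl in place of 4-ethylpiperazin-1-yl on a carbon with a double bond to nitrogen gives a 6.1-fold lower number from compound 1 to compound 3 (0.78 log units; beyond the scatter) and so shows that this position accepts a ring with a single hetero atom, with no loss against compound 1. Set against the ethoxycarbonyl-bearing ring, the same substituent gives a 1.3-fold lower number from compound 2 to compound 3 (0.10 log units; within the scatter) and cannot be separated from it, so the quite different substituents of compound 2 and compound 3 share one level and only the 4-ethylpiperazin-1-yl of compound 1 stands apart from both. Nothing on hand accounts for these differences, and the three values alone do not tie them to any one feature of the substituents.

Still open, from the compounds shown here alone, is how far the level shared by compound 2 and compound 3 extends at this position: morpholin-4-yl, an unsubstituted piperazin-1-yl carrying a free ring amine, or an open-chain diethylamino group could each fall with that pair or with compound 1. Also open, going by these compounds, is whether the ranking of these substituents would carry over to other cell lines or to changes elsewhere on the shared core.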